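Chain extension on two indole cores against an eicosanoid receptor

This account rests on a few compounds, and the source may have more. Where it says the series, first, only, none or still open, it means among the compounds named here.

Measured compounds:
compound 1 `CC(CC(=O)O)CC(=O)n1c(CCCCCCc2ccccc2)cc2ccc(Cl)cc21`, 12 nM
compound 2 `CC(CC(=O)O)CC(=O)n1c(CCCCCc2ccccc2)cc2ccc(Cl)cc21`, 2.1 nM
compound 3 `CC(CC(=O)O)CC(=O)c1c(CCCCc2ccccc2)n(C)c2ccc(Cl)cc12`, 38 nM

Of the compounds shown here, three have been tested in a functional assay for antagonist activity at Oxoeicosanoid receptor 1 (Homo sapiens), read by fluorescence and calcium flux, with stated times of 2 min and 1 min; on this read-out lower numbers stand for stronger inhibition and higher numbers for weaker inhibition. Compound 2 gives 2.1 nM, and compound 1, which differs from it by benzyl in place of phenyl on a saturated chain carbon, five bonds along the chain from an aromatic carbon, gives 12 nM, a step of a 5.7-fold higher number from compound 2 to compound 1 (0.76 log units; beyond the scatter). Compound 3 is built on a different core; how its core differs from that of compound 2 is not broken down here. In this assay compound 3 gives 38 nM, the highest of the three numbers.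

Compound 4 `CC(CC(=O)O)CC(=O)c1c(CCCCCc2ccccc2)n(C)c2ccc(Cl)cc12` is not yet measured. It differs from compound 3 by benzyl in place of phenyl on a saturated chain carbon, four bonds along the chain from an aromatic carbon. Going by the values given here, this is the same kind of change as the one from compound 2 to compound 1, but the place is not the same: there the change sits five bonds along the chain from an aromatic carbon, here four bonds along the chain from an aromatic carbon. Because the measured step of a 5.7-fold higher number from compound 2 to compound 1 (0.76 log units; beyond the scatter) runs in the opposite direction of chain length from the one asked here, and because compound 2, with the benzyl-extended chain, gives 2.1 nM, the lowest number seen, compound 4 is expected to give a somewhat lower number than compound 3, an estimated step of a 2.5-fold lower number from compound 3 to compound 4 (0.40 log units; beyond the scatter). The estimate for compound 4 is 15 nM, expected between 3 nM and 70 nM.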

Compound 4, half-maximal inhibitory concentration: 11 nM
Compound 4: the middle estimate sits 1.4-fold (0.13 log units) above what was measured; the range from low to high includes it.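

In this assay, benzyl in place of phenyl on a saturated chain carbon gives a 3.5-fold lower number from compound 3 to compound 4 (0.54 log units; beyond the scatter), so the change lowers the number on this core but raises it on the core of compound 2, and the two steps differ: the same change on two cores in this assay, a 5.7-fold higher number (0.76 log units; beyond the scatter) from compound 2 to compound 1 and a 3.5-fold lower number (0.54 log units; beyond the scatter) from compound 3 to compound 4, 20-fold (1.30 log units) apart, beyond the scatter of two such steps For these two pairs, then, neither the direction nor the size of the step carries over from one core to the other. The pairs do not show what sets the two steps apart, as the cores differ and the change also sits in a different place on each, four bonds along the chain from an aromatic carbon on one and five on the other.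

The compounds shown leave open how a longer chain than that of compound 4 would read on its core, and how a shorter chain than that of compound 2 would read on its own. They also leave open whether a fluorine in place of the chlorine would alter either step.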